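Selenium-bearing core: pentyl in place of the selenol hydrogen

The source may report more compounds than this note shows. Statements on the series, on what has been measured and on what is new or still open speak of the compounds shown alone.

Of the compounds shown here, two have been measured. Compound 1 `CCCCC[Se]c1nc([Se]CCCCC)c2cccnc2n1` carries two pentylseleno groups on the shared core; in a functional assay on HT-29 cells (Homo sapiens) for cytotoxicity, read by MTT assay, with a stated time of 72 h (a higher number here means that more compound is tolerated, a lower number that less compound is tolerated), compound 1 gives > 100000 nM, which is a limit of the assay and not a number. Compound 2 `Nc1nc([SeH])nc2ncccc12` carries an amino group and a selenol on the same core. In this assay compound 2 gives > 100000 nM, again a limit rather than a number. Compound 2 thus stands at the edge of what has been seen: the limit of > 100000 nM in this assay, at which 2 of the 2 values shown sit. Among the measured compounds shown here, no two measured compounds differ in only one place, so no measured step exists.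

Compound 3 `CCCCC[Se]c1nc(N)c2cccnc2n1` differs from compound 2 by pentyl in place of hydrogen on a selenium. Compound 1 also carries pentyl on selenium and sits at the limit > 100000 nM. Given that, no step beyond the scatter is expected in this assay for this change. Compound 3 is expected to give 100000 nM in this assay, within 30000 nM to 300000 nM, most likely again reported only as a limit. The expected step is a number no higher from compound 2 to compound 3 (the limit leaves the size open).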

Compound 3, concentration lethal to 50% of the cells: 62100 nM
For compound 3 the middle estimate is 1.6-fold (0.21 log units) above the measured one; measured number inside the range.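

In this assay, among the compounds shown here, compound 3 gives 62100 nM, the first read number.

The other two compounds stay at a limit: the limit of > 100000 nM in this assay, at which 2 of the 3 values shown sit.

Pentyl in place of hydrogen on a selenium gives an at least 1.6-fold lower number from compound 2 to compound 3 (0.20 log units; that floor lies within the scatter), so this change now has a lower bound on its size, though not one that clears the scatter. One nitrogen atom in place of a group of 6 heavy atoms on an aromatic carbon gives an at least 1.6-fold lower number from compound 1 to compound 3 (0.20 log units; that floor lies within the scatter), which also stays a floor within the scatter.

As far as these compounds go, both steps start from a limit, so the true size of either remains open. Also open, from the compounds shown here alone, is how the number would respond to a longer chain such as octyl on the selenium, or to a carboxylic acid in place of the amino group.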